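The source may hold more compounds than are shown below. What is called first, only, known or untested is meant among the compounds shown, and "the series" means these compounds.

In a functional assay on HT-29 cells (Homo sapiens) for inhibition, with a stated time of 72 h (a lower number here means a stronger inhibitor, a higher number a weaker inhibitor), three compounds sharing one core have numbers: compound 1 `COc1ccc(S(=O)(=O)N2CCc3cccc(-c4ccc(F)c(F)c4)c32)cc1` gives 57 nM and compound 2 `COc1ccc(S(=O)(=O)N2CCc3cccc(-c4ccc(F)cc4)c32)cc1` gives 85.5 nM while compound 3 `COc1ccc(S(=O)(=O)N2CCc3cccc(-c4cccc(F)c4)c32)cc1` gives 119 nM in the same test. The closest gap is a 1.4-fold higher number from compound 2 to compound 3 (0.14 log units; within the scatter) and the wider one, a modest gap, is a 2.1-fold higher number from compound 1 to compound 3 (0.32 log units; beyond the scatter) on these numbers. Compound 4 `COc1ccc(S(=O)(=O)N2CCc3cccc(-c4ccc(O)cc4)c32)cc1` carries 4-hydroxyphenyl in place of 3-fluorophenyl on an aromatic carbon and has no number yet. Going by the values given here, the nearest guides are fluoro changes only, a 1.5-fold higher number from compound 1 to compound 2 (0.18 log units; within the scatter) and the gap already given, and no measured compound carries a hydroxy group. The expected change is therefore small, a 1.3-fold higher number from compound 3 to compound 4 (0.10 log units; within the scatter) and so none beyond the scatter. For compound 4 the estimate is 150 nM with an expected range from 50 nM to 450 nM in this assay.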

Compound 4, half-maximal inhibitory concentration: 133 nM
Compound 4: the middle estimate sits 1.1-fold (0.05 log units) above what was measured; low and high end bracket the measured number.
By their numbers in this assay, from the lowest: compounds 1, 2, 3 and 4 (each within the scatter of the next, the first and the last beyond it).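

In this assay, this position accepts a hydroxy group, with its hydrogen-bond donor and acceptor, in place of a fluoro-substituted ring without moving beyond the scatter of either single-fluoro compound (a 1.1-fold higher number from compound 3 to compound 4 (0.05 log units; within the scatter); a 1.6-fold higher number from compound 2 to compound 4 (0.19 log units; within the scatter)). Only the comparison with the 3,4-difluorophenyl compound goes beyond the scatter (a 2.3-fold higher number from compound 1 to compound 4 (0.37 log units; beyond the scatter)), and that step is modest. From the compounds shown here alone, whether an amine or a carboxylic acid in place of the hydroxy group would keep the number in this range remains open. What lies behind these numbers is also open, as nothing given here explains them.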